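One swap on compound 1, and what to expect

The compounds below may be only part of what the source reports. "The series", "measured", "known", "first", "only" and "open" are said of these compounds alone.

Going by the values given here, in a physicochemical assay for solubility, in phosphate buffer, with a stated time of 2 h, at pH 6.5 (on this read-out lower numbers stand for lower solubility and higher numbers for higher solubility), compound 1 `Cc1ccncc1C(=O)N1CC(Oc2cncc(N3C(=O)c4ccc(Cl)cc4C3(C)C)c2)C1` gives 290 ug/mL and stands highest of the three compounds measured so far. In the same test, this assay, compound 3 `CC1(C)c2cc(Cl)ccc2C(=O)N1c1cncc(N2CCN(S(C)(=O)=O)CC2)c1` gives 91 ug/mL and compound 2 `Cn1cc(C(=O)N2CC3(C2)CN(c2cncc(N4C(=O)c5ccc(Cl)cc5C4(C)C)c2)C3)cn1` gives 44 ug/mL. Both of these numbers lie under that of compound 1 by more than the usual scatter.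

The next compound, compound 4 `CCS(=O)(=O)N1CC(Oc2cncc(N3C(=O)c4ccc(Cl)cc4C3(C)C)c2)C1`, keeps the core of compound 1 but carries ethylsulfonyl in place of (4-methylpyridin-3-yl)carbonyl on an amine nitrogen in a ring. Among the compounds with values here, no measured pair of compounds shows this change on its own, so any expectation is indirect. Within the data shown here, the closest guide is compound 3 at 91 ug/mL, the only measured compound that also carries a sulfonyl group. A fall beyond the scatter is therefore expected, and the estimated size of the step is a 4.1-fold lower number from compound 1 to compound 4 (0.62 log units; beyond the scatter) (an expectation, not a measurement). For compound 4 the expected value is 70 ug/mL (estimated range 25 ug/mL to 180 ug/mL).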

Compound 4, solubility: 78 ug/mL
For compound 4 the middle estimate is 1.1-fold (0.05 log units) below the measured one, within the range that was stated.
By their numbers in this assay, from the lowest: compounds 2, 4 and 3 (each within the scatter of the next, the first and the last beyond it); then compound 1.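

On the amine nitrogen of the four-membered ring, the group matters: in this assay, ethylsulfonyl in place of (4-methylpyridin-3-yl)carbonyl gives a 3.7-fold lower number from compound 1 to compound 4 (0.57 log units; beyond the scatter) and a step beyond the usual scatter, with the rest of compound 1 unchanged. Going by these compounds alone, this is the first measured pair that differs in one place only, so this step can be read directly rather than inferred from compounds that differ in several places. The swap removes a six-membered aromatic ring and brings in a sulfonyl group with fewer heavy atoms, and no measurement here separates these differences or explains the step.

The compounds shown leave open whether the ring or the carbonyl link matters more at this position. An acetyl group would keep the carbonyl without the ring, and butylsulfonyl would test a longer chain on the sulfonyl.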